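Removing one methoxy group from compound 3

The source may hold more compounds than are shown below. What is called first, only, known or untested is meant among the compounds shown, and "the series" means these compounds.

Compound 1 `COc1cc(-c2cc(/C=C/C(=O)c3ccc(N)cc3)[nH]n2)cc(OC)c1OC` gives 92% in a functional assay on HOP-62 cells (Homo sapiens) for cytotoxicity, read by sulforhodamine B assay, with a stated time of 48 h, tested at 0.1 uM; a lower number here means a stronger effect, a higher number a weaker effect of the compound at the concentration tested.
Compound 2 `COc1cc(-c2cc(/C=C/C(=O)c3ccc(Cl)c(Cl)c3)[nH]n2)cc(OC)c1OC` gives 101% in this assay.
Compound 3 `COc1ccc(C(=O)/C=C/c2cc(-c3cc(OC)c(OC)c(OC)c3)n[nH]2)cc1OC` gives 100% in this assay.

Compound 3 stands second highest of the three numbers shown; the step nearest to it is a number 1 percentage points lower from compound 2 to compound 3 (within the scatter), and the one furthest is a number 8 percentage points higher from compound 1 to compound 3 (within the scatter). Compound 4 `COc1ccc(C(=O)/C=C/c2cc(-c3cc(OC)c(OC)c(OC)c3)n[nH]2)cc1` arises from compound 3 by a single change: hydrogen in place of methoxy on an aromatic carbon. Within the data shown here, no measured step touches that place. The three steps seen so far, a number 9 percentage points higher from compound 1 to compound 2 (within the scatter), a number 8 percentage points higher from compound 1 to compound 3 (within the scatter) and a number 1 percentage points lower from compound 2 to compound 3 (within the scatter), each exchange the whole ring on the carbonyl carbon, and every one of them stays within the scatter. The smaller change leading to compound 4 is therefore expected to give no step beyond the scatter, a number 1 percentage points lower from compound 3 to compound 4 (within the scatter). Compound 4 is estimated at 99%, with a range from 88% to 108%.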

Compound 4, a percentage reported as activity, at one concentration (the size of the read-out at that concentration, not a potency): 102%
The estimate for compound 4 lay 3 percentage points below the measured number; the measured number falls inside the stated range.
By their numbers in this assay, from the lowest: compounds 1, 3, 2 and 4 (each within the scatter of the next).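

In this assay, among these compounds, this is the first look at a single methoxy group on the ring on the carbonyl carbon, and taking it away to reach the 4-methoxyphenyl ring stays within the scatter (a number 2 percentage points higher from compound 3 to compound 4 (within the scatter)). Among the compounds shown here, the steps from the other two rings also stay within it (a number 1 percentage points higher from compound 2 to compound 4 (within the scatter); a number 10 percentage points higher from compound 1 to compound 4 (within the scatter)), so no compound here separates from the others at this one concentration. No evidence bears on this result. On these data alone, whether a hydroxy group, an ethoxy group or a fluorine atom on this aromatic carbon would give a number beyond the scatter stays open.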